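This account rests on a few compounds, and the source may have more. Where it says the series, first, only, none or still open, it means among the compounds named here.

In a functional assay on HCT-116 cells (Homo sapiens) for antiproliferative activity, read by MTT assay, with a stated time of 72 h (a higher number here means a weaker inhibitor, a lower number a stronger inhibitor), three esters of a shared core have been measured. Compound 1 `CCC(CO)(CO)C(=O)Oc1ccc(/C=C/C(=O)/C=C(O)/C=C/c2ccc(O)c(OC)c2)cc1OC` gives 11400 nM, compound 2 `COc1ccc(/C=C/C(=O)/C=C(O)/C=C/c2ccc(OC)c(OC(=O)C(C)(CO)CO)c2)cc1OC(=O)C(C)(CO)CO` gives 2790 nM, and compound 3 `COc1ccc(/C=C/C(O)=C/C(=O)/C=C/c2ccc(OC)c(OC(=O)C(C)(CO)CO)c2)cc1O` gives 1950 nM. Compound 3 thus sits at the low end of these numbers, level within the scatter with compound 2 and clearly apart from compound 1.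

The next compound, compound 4 `CCC(CO)(CO)C(=O)Oc1cc(/C=C/C(=O)/C=C(O)/C=C/c2ccc(OC)c(O)c2)ccc1OC`, differs from compound 3 by one small change in the ester: methyl in place of hydrogen on a saturated chain carbon, two bonds along the chain from a carbonyl carbon. This is methyl in place of hydrogen on a saturated chain carbon, two bonds along the chain from a carbonyl carbon, which turns 1,1-bis(hydroxymethyl)ethyl into 1,1-bis(hydroxymethyl)propyl.

Within the data shown here, the only measured step, a 1.4-fold lower number from compound 2 to compound 3 (0.16 log units; within the scatter), removes a whole (1,1-bis(hydroxymethyl)ethyl)carbonyl and stays within the scatter, so it bears on this methyl only loosely. Compound 1 also carries the 1,1-bis(hydroxymethyl)propyl group and stands at 11400 nM, but it differs from compound 4 elsewhere, so its number does not isolate the change. Among the measured compounds shown here, no measured pair isolates it. A shift beyond the scatter in this assay is therefore not expected, and any drift would more likely be slightly upward. The expected step is a 1.3-fold higher number from compound 3 to compound 4 (0.11 log units; within the scatter). For compound 4 the estimated value is 2500 nM, with an expected range of 1100 nM to 6000 nM.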

Compound 4, half-maximal inhibitory concentration: 3640 nM
The estimate for compound 4 lay 1.5-fold (0.16 log units) below the measured number; low and high end bracket the measured number.
By their numbers in this assay, from the lowest: compounds 3, 2 and 4 (each within the scatter of the next); then compound 1.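

In this assay the methyl in place of hydrogen on a saturated chain carbon, two bonds along the chain from a carbonyl carbon, can now be read on its own, in a pair that differs in this one place (a 1.9-fold higher number from compound 3 to compound 4 (0.27 log units; within the scatter)). The change from 1,1-bis(hydroxymethyl)ethyl to 1,1-bis(hydroxymethyl)propyl therefore stays within the scatter, which the earlier step, the removal of a whole ester group, could only hint at. At this position, going from methyl to ethyl leaves no shift that can be told apart from repeat measurements. Nothing in the data shown gives a reason for the size of this step.

A single added methyl says little about a longer chain such as propyl or butyl, or about an amine or a carboxylic acid at this carbon. Among these compounds, it also remains open whether the same change would read the same way on another ester of the shared core, such as compound 2, since only this one pair isolates it.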